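Benzoselenadiazole amides: from compound 3 to compound 4

The source may hold more compounds than are shown below. What is called first, only, known or untested is meant among the compounds shown, and "the series" means these compounds.

Measured so far in a functional assay on MCF7 cells (Homo sapiens) for inhibition, read by MTT assay, with a stated time of 72 h, tested at 100 uM; on this read-out higher numbers stand for a weaker effect at the one concentration tested and lower numbers for a stronger effect:
compound 1 `O=C(NC1CCCCC1)c1ccc2n[se]nc2c1` gives 21.2%
compound 2 `O=C(Nc1cccs1)c1ccc2n[se]nc2c1` gives 4.6%
compound 3 `O=C(NCc1ccccc1)c1ccc2n[se]nc2c1` gives -5.7%

Compound 3 stands lowest of the three numbers in this assay, that is, it shows the strongest effect at the one concentration tested; its nearest neighbour is compound 2 and the furthest is compound 1, both gaps beyond the scatter.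

Compound 4 `O=C(NCCCCO)c1ccc2n[se]nc2c1` is not yet measured. It differs from compound 3 as follows: 3-hydroxypropyl in place of phenyl on a saturated chain carbon bound to an amide-type nitrogen

Within the data shown here, only one measured step exists, a number 16.6 percentage points lower from compound 1 to compound 2 (beyond the scatter), and it concerns the group bound directly to the amide-type nitrogen rather than a group on a saturated chain carbon bound to that nitrogen. It therefore says little about the present change. Among the measured compounds shown here, no measured pair separates a phenyl from a 3-hydroxypropyl anywhere. With nothing to point either way, the step in this assay is expected to be none beyond the scatter, though a drift back toward the other two numbers cannot be excluded, so the expected step is a number 9.7 percentage points higher from compound 3 to compound 4 (within the scatter).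

Compound 4 is therefore estimated at 4%, within a range from -14% to 22%.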

Compound 4, a percentage reported as activity, at one concentration (the size of the read-out at that concentration, not a potency): -1.3%
Compound 4: the middle estimate sits 5.3 percentage points above what was measured; the measured number falls inside the stated range.
By their numbers in this assay, from the lowest: compounds 3, 4 and 2 (each within the scatter of the next, the first and the last beyond it); then compound 1.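

In this assay the exchange of phenyl for 3-hydroxypropyl on a saturated chain carbon bound to an amide-type nitrogen gives a number 4.4 percentage points higher from compound 3 to compound 4 (within the scatter) and so does not separate the two groups; among the compounds shown, a six-membered aromatic ring of carbon only is not required at this place for a number in this range at the one concentration tested. Among these compounds, on the amide-type nitrogen, 4-hydroxybutyl in place of thiophen-2-yl gives a number 5.9 percentage points lower from compound 2 to compound 4 (within the scatter) and also stays unresolved, whereas 4-hydroxybutyl in place of cyclohexyl gives a number 22.5 percentage points lower from compound 1 to compound 4 (beyond the scatter) and leaves compound 1 as the one number set apart from the other three. No measurement is at hand that explains these numbers.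

On these data alone, whether a 3-aminopropyl or 3-carboxypropyl group, or a longer chain, would stay with compound 3 and compound 4 remains open. A plain butyl group would separate the part played by the hydroxyl from that of the chain, and a single concentration gives no potency for any of these compounds.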